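Replacing the fluorinated anisole at the alkyne end

The source may hold more compounds than are shown below. What is called first, only, known or untested is meant among the compounds shown, and "the series" means these compounds.

Compound 1 `COc1ccc(C#Cc2ccc(C(=O)N3CCC[C@@H](CO)C3)cc2)c(F)c1` is an alkyne-linked aryl amide bearing a hydroxymethyl-substituted piperidine on the carbonyl carbon. In a functional assay on TREX cells for negative allosteric modulation of metabotropic glutamate receptor 3 (Rattus norvegicus), read by calcium flux, with a stated time of 2.5 min (a higher number here means a weaker inhibitor, a lower number a stronger inhibitor), compound 1 gives > 10000 nM, and this is a limit of the assay rather than a number (the limit of > 10000 nM in this assay, at which 1 of the 3 values shown sits). Two related amides differ from compound 1 only at the amide end. Compound 2 `COc1ccc(C#Cc2ccc(C(=O)N3CC4CCC(O)C4C3)cc2)cc1` gives 5500 nM in this assay, and compound 3 `COc1ccc(C#Cc2ccc(C(=O)N3CC[C@H](O)C3)cc2)cc1` gives 27500 nM. Between these two, the swap on the carbonyl carbon produces a 5.0-fold higher number from compound 2 to compound 3 (0.70 log units; beyond the scatter).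

Compound 4 `CSc1ccc(C#Cc2ccc(C(=O)N3CCC[C@@H](CO)C3)cc2)cc1` keeps the amide of compound 1 unchanged and alters the other end of the molecule: 4-(methylsulfanyl)phenyl in place of 2-fluoro-4-methoxyphenyl on a triple-bonded carbon. Within the data shown here, none of the measured steps touches this aryl group. Among the measured compounds shown here, the single measured step, from compound 2 to compound 3, concerns the amine attached to the carbonyl carbon and therefore carries no information about a change at the triple-bonded carbon. Since compound 1 itself sits only at a limit, neither the direction nor the size of the step to compound 4 can be read from the numbers in hand. Compound 4 is nonetheless expected to give roughly 9000 nM in this assay, somewhere between 2500 nM and 35000 nM. That expectation corresponds to a step of an at least 1.1-fold lower number from compound 1 to compound 4 (0.04 log units; that floor lies within the scatter), which rests on no measured comparison.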

Compound 4, half-maximal inhibitory concentration: > 10000 nM
Compound 4 was reported as a limit; the forecaster's own chance of this, stated with the estimate: 45%; at least 1.1-fold (0.04 log units) between middle value and limit.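

In this assay, among these compounds, compound 4 gives > 10000 nM and this is a limit of the assay, as the result for compound 1 is too, so no step between compound 1 and compound 4 can be read: the limit of > 10000 nM in this assay, at which 2 of the 4 values shown sit.

The compounds shown leave open whether 4-(methylsulfanyl)phenyl in place of 2-fluoro-4-methoxyphenyl on a triple-bonded carbon changes the value at all.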